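Cyclopropyl to 4-fluorophenyl on the ring nitrogen of the core

This account rests on a few compounds, and the source may have more. Where it says the series, first, only, none or still open, it means among the compounds named here.

Measured compounds:
compound 1 `CC(C)c1onc(-c2c(Cl)cccc2Cl)c1COc1ccc(-c2nc3ccc(C(=O)O)cc3n2Cc2ccc(F)cc2)cc1` 1140 nM
compound 2 `CCCn1c(-c2ccc(OCc3c(-c4c(Cl)cccc4Cl)noc3C(C)C)cc2)nc2ccc(C(=O)O)cc21` 1400 nM
compound 3 `CC(C)c1onc(-c2c(Cl)cccc2Cl)c1COc1ccc(-c2nc3ccc(C(=O)O)cc3n2C2CC2)cc1` 3200 nM

In an assay on HEK-293T cells for antagonist activity at vitamin D3 receptor (Homo sapiens), read by a luciferase reporter, with a stated time of 24 h (on this read-out lower numbers stand for stronger inhibition and higher numbers for weaker inhibition), compound 3 stands at the highest number of the three. Its nearest neighbour is compound 2, with a 2.3-fold higher number from compound 2 to compound 3 (0.36 log units; beyond the scatter) separating them, and the furthest is compound 1, with a 2.8-fold higher number from compound 1 to compound 3 (0.45 log units; beyond the scatter). Both steps lie beyond the scatter, so compound 3 is the weakest of the measured set on this read-out.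

Compound 4 `CC(C)c1onc(-c2c(Cl)cccc2Cl)c1COc1ccc(-c2nc3ccc(C(=O)O)cc3n2-c2ccc(F)cc2)cc1` differs from compound 3 only at the ring nitrogen: 4-fluorophenyl in place of cyclopropyl on an aromatic nitrogen. Going by the values given here, the step that bears most directly on this change is the one from compound 1 to compound 3, where the 4-fluorobenzyl was exchanged for cyclopropyl and the number rose by a 2.8-fold higher number from compound 1 to compound 3 (0.45 log units; beyond the scatter). The new 4-fluorophenyl sits one chain carbon closer to the ring nitrogen than the 4-fluorobenzyl of compound 1, so it is not the same group, but the aromatic ring carrying fluorine returns. The step from compound 2 to compound 3, a 2.3-fold higher number from compound 2 to compound 3 (0.36 log units; beyond the scatter), points the same way: leaving cyclopropyl has so far meant a lower number. Compound 4 is therefore expected to come in lower than compound 3 by about a 2.5-fold lower number from compound 3 to compound 4 (0.39 log units; beyond the scatter). The estimate for compound 4 in this assay is 1300 nM, with a range from 500 nM to 3500 nM.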

Compound 4, half-maximal inhibitory concentration: 2410 nM
For compound 4 the middle estimate is 1.9-fold (0.27 log units) below the measured one, and the stated range covers the measured number.
By their numbers in this assay, from the lowest: compounds 1, 2, 4 and 3 (each within the scatter of the next, the first and the last beyond it).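

In this assay, 4-fluorophenyl on the aromatic nitrogen cannot be told apart from cyclopropyl (a 1.3-fold lower number from compound 3 to compound 4 (0.12 log units; within the scatter)) or from propyl (a 1.7-fold higher number from compound 2 to compound 4 (0.24 log units; within the scatter)), so these three groups give no clear order at this position. Only the 4-fluorobenzyl of compound 1 separates from the directly attached 4-fluorophenyl (a 2.1-fold higher number from compound 1 to compound 4 (0.33 log units; beyond the scatter)), which shows that bringing back the fluorine-bearing aromatic ring without its chain carbon does not restore the number of compound 1. No measurement at hand gives a reason for these steps.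

The compounds shown leave open whether unsubstituted benzyl or phenethyl on the same nitrogen would match or pass 4-fluorobenzyl. They also leave open whether a butyl chain would stay level with propyl.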